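From Isopropyl to Methoxy: What to Expect of Compound 4

The source may hold more compounds than are shown below. What is called first, only, known or untested is meant among the compounds shown, and "the series" means these compounds.

compound 1, `CC(C)c1ccccc1NC(=O)N[C@H](C)c1ccccc1`, gives 103% in an ADME assay on the whole organism with Oryza sativa as the target, tested at 0.1 uM; a higher number here means a weaker effect of the compound at the concentration tested, a lower number a stronger effect
compound 2, `CC(C)c1ccccc1NC(=O)N[C@@H](C)c1ccccc1`, gives 99% in this assay
compound 3, `C[C@H](NC(=O)Nc1ccc(C(F)(F)F)cc1)c1ccccc1`, gives 94% in this assay

Compound 1 stands at the top of these three numbers, yet compound 2 and compound 3 both lie within the scatter of it. The change to compound 4, `COc1ccccc1NC(=O)N[C@H](C)c1ccccc1`, is methoxy in place of isopropyl on an aromatic carbon. Among the compounds with values here, the only measured step, a number 4 percentage points lower from compound 1 to compound 2 (within the scatter), rests on a change of configuration alone, because of the fact that compounds 1 and 2 differ only in the configuration as drawn, and so says nothing about a change of substituent. Compound 3 carries trifluoromethyl rather than isopropyl and its value also sits within the scatter of compound 1. Within the data shown here, no measured step therefore bears on methoxy against isopropyl, and compound 4 is expected to move from compound 1 by no more than the scatter: a number 5 percentage points lower from compound 1 to compound 4 (within the scatter). For compound 4 the estimate in this assay is 98%, between 84% and 110%.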

Compound 4, a percentage reported as activity, at one concentration (the size of the read-out at that concentration, not a potency): 100%
Compound 4: the middle estimate sits 2 percentage points below what was measured; measured number inside the range.
By their numbers in this assay, from the lowest: compounds 3, 2, 4 and 1 (each within the scatter of the next).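

In this assay, within the data shown here, methoxy in place of isopropyl gives the only measured substituent step at this place, on an aromatic carbon ortho to a large group, and it amounts to a number 3 percentage points lower from compound 1 to compound 4 (within the scatter). The earlier step changed configuration alone, whereas this one shows that a change of group here, bringing in a hydrogen-bond acceptor, does not separate compound 4 from compound 1. No evidence at hand bears on this step. As far as these compounds go, whether an amine or a carboxylic acid at this place would give a step beyond the scatter remains open. So does whether methoxy would read the same with the stereocentre drawn S.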